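Swapping an Amine for an Amide on a Chain

The source may report more compounds than this note shows. Statements on the series, on what has been measured and on what is new or still open speak of the compounds shown alone.

Compound 1 `Cc1nc2c(N)ncnc2n1[C@@H]1O[C@H](CN(C)CCN)[C@@H](O)[C@H]1O` is one of two measured compounds, and in an assay on isolated protein for inhibition of S-adenosylmethionine decarboxylase proenzyme (Homo sapiens) (on this read-out higher numbers stand for weaker inhibition and lower numbers for stronger inhibition), compound 1 gives 88000 nM, the lower of the two numbers. Compound 2 `CNc1nc2c(N)ncnc2n1[C@@H]1O[C@H](CN(C)CCCN)[C@@H](O)[C@H]1O` gives 440000 nM in this assay, a gap beyond the usual scatter. Compound 3 `Cc1nc2c(N)ncnc2n1[C@@H]1O[C@H](CN(C)CCC(N)=O)[C@@H](O)[C@H]1O` differs from compound 1 in a single place: carbamoyl in place of amino on a saturated chain carbon, two bonds along the chain from an amine nitrogen. Among the compounds with values here, no measured pair shows this exact change, so the step is expected to be modest and toward weaker inhibition, a 2.8-fold higher number from compound 1 to compound 3 (0.45 log units; beyond the scatter). Compound 3 is therefore estimated at 250000 nM in this assay, with a range from 80000 nM to 800000 nM.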

Compound 3, half-maximal inhibitory concentration: 400 nM
Beside the measured number, compound 3's estimate is 630-fold (2.80 log units) above it; the measured number lies below the stated range.
By their numbers in this assay, from the lowest: compound 3; then compound 1; then compound 2.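

In this assay, putting carbamoyl in place of amino on this chain gives a 220-fold lower number from compound 1 to compound 3 (2.34 log units; beyond the scatter) and so marks this position as highly sensitive to what sits on it. Compound 1 and compound 2 differ in more than one place, so they could not show what a single change here does. Nothing measured here explains the size of this step. Still open, going by these compounds, is how much depends on the carbamoyl itself. A carboxylic acid, a methyl ester or a longer chain ending in carbamoyl at this place would help to tell.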